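The source may report more compounds than this note shows. Statements on the series, on what has been measured and on what is new or still open speak of the compounds shown alone.

Compound 1 `CCC/C=C/C(=O)N(Cc1ccc(OC)c(O)c1)c1cc(OC)c(OC)c(OC)c1` stands lowest of the three numbers recorded here. In a functional assay on HCT-116 cells (Homo sapiens) for inhibition, read by MTT assay, with a stated time of 48 h (on this read-out lower numbers stand for stronger inhibition and higher numbers for weaker inhibition), compound 1 gives 95 nM. Compound 2 `C/C=C/C(=O)N(Cc1ccc(OC)c(C)c1)c1cc(OC)c(OC)c(OC)c1` gives 23500 nM in this assay, and compound 3 `COc1ccc(CNc2cc(OC)c(OC)c(OC)c2)cc1Br` gives 48100 nM, both far beyond the scatter from compound 1, so compound 1 is the most potent of the three.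

Compound 4 `COc1ccc(CN(C(=O)C[Se]C#N)c2cc(OC)c(OC)c(OC)c2)cc1O` differs from compound 1 by a group of 4 heavy atoms (2 carbon, 1 nitrogen, 1 selenium; no ring) in place of a group of 5 heavy atoms (5 carbon; no ring), on a carbonyl carbon. Going by the values given here, no step between two measured compounds matches this change, so the size of its effect is uncertain. Compound 4 is expected to give a somewhat weaker result than compound 1, with the step of a 4.2-fold higher number from compound 1 to compound 4 (0.62 log units; beyond the scatter) expected to be modest but possibly beyond the scatter. Compound 4 is therefore estimated at 400 nM, within a range from 60 nM to 3000 nM.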

Compound 4, half-maximal inhibitory concentration: 310 nM
Estimate against measurement, compound 4: 1.3-fold (0.11 log units) above; the range from low to high includes it.
By their numbers in this assay, from the lowest: compound 1; then compound 4; then compound 2; then compound 3.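

On the carbonyl carbon, replacing pent-1-en-1-yl with the selenium-bearing group with its triple bond gives a 3.3-fold higher number from compound 1 to compound 4 (0.51 log units; beyond the scatter) in this assay and so costs only modest potency. This position therefore keeps submicromolar activity without the double bond of the pent-1-en-1-yl chain, with a quite different group in its place. Nothing measured here explains the loss. The compounds shown leave open whether selenium itself matters, as no sulfur counterpart appears among them. On these data alone, how an amine or a longer chain on this carbonyl carbon would compare also remains open.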